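From Dimethoxybenzyl to Bromobenzyl: an Expected Growth Inhibition

This account rests on a few compounds, and the source may have more. Where it says the series, first, only, none or still open, it means among the compounds named here.

Compound 1 `COc1ccc(CNCCCNS(=O)(=O)c2cc(C(F)(F)F)cc(C(F)(F)F)c2)cc1OC` is the weakest inhibitor among the three measured analogues. In a functional assay on BXPC-3 cells (Homo sapiens) for inhibition, read by MTT assay, with a stated time of 72 h (a lower number here means a stronger inhibitor of growth, a higher number a weaker inhibitor of growth), compound 1 gives 13000 nM. Its companions keep the shared core and differ only in the aryl group on a saturated chain carbon bound to an amine nitrogen: compound 2 `O=S(=O)(NCCCNCc1cccc(Cl)c1)c1cc(C(F)(F)F)cc(C(F)(F)F)c1` gives 3800 nM in this assay, and compound 3 `O=S(=O)(NCCCNCc1ccccc1Cl)c1cc(C(F)(F)F)cc(C(F)(F)F)c1` gives 11000 nM. The step of a 3.4-fold lower number from compound 1 to compound 2 (0.53 log units; beyond the scatter) is modest but beyond the scatter, whereas the step of a 1.2-fold lower number from compound 1 to compound 3 (0.07 log units; within the scatter) stays within it, and the step of a 2.9-fold higher number from compound 2 to compound 3 (0.46 log units; beyond the scatter) shows that where the chlorine sits on the ring matters by a similar modest margin.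

Compound 4 `O=S(=O)(NCCCNCc1ccc(Br)cc1)c1cc(C(F)(F)F)cc(C(F)(F)F)c1` has not yet been measured. Relative to compound 1 the change is 4-bromophenyl in place of 3,4-dimethoxyphenyl on a saturated chain carbon bound to an amine nitrogen. Both measured steps from compound 1 bear on this: one swap of the dimethoxyphenyl for a halophenyl lowered the number modestly, the other left it unchanged. Going by the values given here, a bromophenyl at a third position has no direct precedent here, so the expected step of a 2.0-fold lower number from compound 1 to compound 4 (0.30 log units; within the scatter) is placed between those two outcomes, leaning toward a small improvement. Compound 4 is therefore estimated at 6500 nM in this assay, with a range from 2500 nM to 16000 nM.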

Compound 4, concentration for 50% growth inhibition: 1500 nM
Compound 4: middle estimate off by 4.3-fold (0.64 log units), on the high side; the whole stated range lies above it.
By their numbers in this assay, from the lowest: compound 4; then compound 2; then compounds 3 and 1 (each within the scatter of the next).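

In this assay, the change to 4-bromophenyl gives an 8.7-fold lower number from compound 1 to compound 4 (0.94 log units; beyond the scatter), showing that the number at this place, on a saturated chain carbon bound to an amine nitrogen, can fall further than either chlorophenyl took it. Compound 4 also stands clear of both chlorophenyl analogues, with a 2.5-fold lower number from compound 2 to compound 4 (0.40 log units; beyond the scatter) and a 7.3-fold lower number from compound 3 to compound 4 (0.87 log units; beyond the scatter), which makes it the strongest inhibitor of growth among the four compounds shown. No measurement here explains why the 4-bromophenyl group gives the lowest number.

Compound 4 differs from compound 2 and compound 3 in both the halogen and its place on the ring, so these compounds cannot separate the contribution of bromine from that of its ring position. A chlorophenyl with chlorine where compound 4 carries its bromine would address the halogen, and a bromophenyl with bromine where compound 2 carries its chlorine would address the ring position, while a longer chain between the two nitrogens remains an open change elsewhere in the molecule.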